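Urea Replaces the Amide on the Chain of Compound 3

The source may hold more compounds than are shown below. What is called first, only, known or untested is meant among the compounds shown, and "the series" means these compounds.

Three compounds share one core. Compound 1 `CCOC(=O)CCCOc1ccc(-n2cnc(-c3ccccc3)c2-c2ccccc2)cc1` and compound 2 `CCOC(=O)CCCOc1cccc(-n2cnc(-c3ccccc3)c2-c2ccccc2)c1` carry an ester-terminated chain on an aryl ring; in an assay on H4 cells for inhibition of Fatty-acid amide hydrolase 1 (Homo sapiens) (a higher number here means a weaker inhibitor, a lower number a stronger inhibitor), compound 1 gives 64 nM and compound 2 gives 91 nM. Compound 3 `CNC(=O)CCCCCCn1c(C)nc(-c2ccccc2)c1-c1ccccc1` instead carries a methyl on the core and a chain on the aromatic nitrogen that ends in an amide; in this assay compound 3 gives 1700 nM, the highest of the three numbers, beyond the scatter from both compound 2 and compound 1. Compound 4 `Cc1nc(-c2ccccc2)c(-c2ccccc2)n1CCCCCCNC(=O)Nc1ccccc1` differs from compound 3 in one place: (phenylcarbamoyl)amino in place of methylcarbamoyl on a saturated chain carbon, six bonds along the chain from an aromatic nitrogen. Going by the values given here, no measured pair shows this change, so its effect is not known here. A lowering of the number is expected, an 8.5-fold lower number from compound 3 to compound 4 (0.93 log units; beyond the scatter). Compound 4 is estimated at 200 nM, with a range from 30 nM to 1500 nM.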

Compound 4, half-maximal inhibitory concentration: 10000 nM
Compound 4: middle estimate off by 50-fold (1.70 log units), on the low side; measured number outside the range, above it.
By their numbers in this assay, from the lowest: compounds 1 and 2 (each within the scatter of the next); then compound 3; then compound 4.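

Going by these compounds alone, this is the first step that differs in one place, and it gives the chain end a direction: in this assay, (phenylcarbamoyl)amino in place of methylcarbamoyl gives a 5.9-fold higher number from compound 3 to compound 4 (0.77 log units; beyond the scatter). On this chain, then, the larger group with its added aromatic ring does not bring the lower number seen with neither compound 1 nor compound 2 in this series. Nothing available here accounts for the rise.

Open, as far as these compounds go, is how a carboxylic acid or an amine would read at this chain end. Also open, from the compounds shown here alone, is whether a shorter or longer chain would alter the effect of the same change.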